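Replacing the Amide Side Chain of Compound 1

The source may hold more compounds than are shown below. What is called first, only, known or untested is meant among the compounds shown, and "the series" means these compounds.

Compound 1 `CCN(CC)CCNC(=O)c1ccc(C(CC)(CC)c2ccc(OCCC(O)(CC)CC)c(C)c2)n1CC` carries a 2-(diethylamino)ethyl group on an amide-type nitrogen. Among the measured compounds shown here, in a functional assay on MCF7 cells (Homo sapiens) for antiproliferative activity, read by MTT assay, with a stated time of 48 h (on this read-out lower numbers stand for stronger inhibition and higher numbers for weaker inhibition), compound 1 gives 550 nM, and it is the only compound here with a number in this assay. Compound 2 `CCOc1ccc(NC(=O)c2ccc(C(CC)(CC)c3ccc(OCCC(O)(CC)CC)c(C)c3)n2CC)cc1` bears a 4-ethoxyphenyl on that nitrogen instead. In this assay compound 2 gives > 50000 nM, which is a limit of the assay rather than a number, as described by the limit of > 50000 nM in this assay, at which 1 of the 2 values shown sits. The step of an at least 90-fold higher number from compound 1 to compound 2 (1.95 log units; beyond the scatter) is large and beyond the scatter.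

Compound 3 `CCn1c(C(=O)NC(CC(=O)O)C(=O)OC)ccc1C(CC)(CC)c1ccc(OCCC(O)(CC)CC)c(C)c1` alters the same nitrogen: a group of 9 heavy atoms (5 carbon, 4 oxygen; no ring) in place of a group of 7 heavy atoms (6 carbon, 1 nitrogen; no ring), on an amide-type nitrogen. The 2-(diethylamino)ethyl group leaves here just as it does in compound 2, and what enters is again no ring. For the measured compounds named here, only the step from compound 1 to compound 2 bears on this change, and it was large, so a loss well beyond the scatter is expected in this assay, though it cannot be told whether compound 3 will yield a number or only the limit. Compound 3 is expected to give about 20000 nM, between 3000 nM and 100000 nM. That estimate means an expected step of a 36-fold higher number from compound 1 to compound 3 (1.56 log units; beyond the scatter).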

Compound 3, half-maximal inhibitory concentration: 10200 nM
Estimate against measurement, compound 3: 2.0-fold (0.29 log units) above; measured number inside the range.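

With compound 3 this amide-type nitrogen gives a measured number for a replacement of the 2-(diethylamino)ethyl group, so the loss on removing that group can now be sized in this assay, and the change brings a 19-fold higher number from compound 1 to compound 3 (1.27 log units; beyond the scatter). The value of compound 2 is a limit of the assay and not a number: the limit of > 50000 nM in this assay, at which 1 of the 3 values shown sits. The two replacements do not give the same result, with an at least 4.9-fold lower number from compound 2 to compound 3 (0.69 log units; beyond the scatter), so the group that enters on this nitrogen matters as well as the one that leaves, although both replacements give higher numbers than the 2-(diethylamino)ethyl group.

The compounds shown leave open whether the tertiary amine of the 2-(diethylamino)ethyl group is the part that counts, a question that a morpholine or pyrrolidine on the same two-carbon chain, or a plain butyl chain with no amine, would address. They also leave open which part of the group in compound 3 accounts for its number, as a simple carboxylic acid chain and a simple methyl ester chain would each test one part of it alone.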